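The source may hold more compounds than are shown below. What is called first, only, known or untested is meant among the compounds shown, and "the series" means these compounds.

Of the compounds shown here, three built on one shared core have been tested in an ADME assay on the whole organism for cytotoxicity, with Artemia salina as the target, with a stated time of 24 h; on this read-out lower numbers stand for an effect already at smaller amounts and higher numbers for an effect only at larger amounts of compound. Compound 1 `Cc1ccc(/C=C/C(=O)c2ccccc2NC(=O)NS(=O)(=O)c2ccc(C)cc2)cc1` gives 15.3 ug/mL, compound 2 `COc1cccc(/C=C/C(=O)c2ccccc2NC(=O)NS(=O)(=O)c2ccc(C)cc2)c1` gives 23.2 ug/mL, and compound 3 `COc1ccc(/C=C/C(=O)c2ccccc2NC(=O)NS(=O)(=O)c2ccc(C)cc2)c(OC)c1` gives 16 ug/mL. Compound 2 stands at the highest of these three numbers, yet the steps of a 1.5-fold higher number from compound 1 to compound 2 (0.18 log units; within the scatter) and a 1.5-fold lower number from compound 2 to compound 3 (0.16 log units; within the scatter) both lie within the scatter, as does a 1.0-fold higher number from compound 1 to compound 3 (0.02 log units; within the scatter).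

Compound 4 `Cc1ccc(S(=O)(=O)NC(=O)Nc2ccccc2C(=O)/C=C/c2cccc(O)c2)cc1` differs from compound 2 by hydrogen in place of methyl on an oxygen on an aromatic ring. Going by the values given here, none of the measured steps touches that oxygen; all three only exchange the aryl group on the double-bonded chain carbon, and all stay within the scatter, so no step beyond the scatter is expected in this assay here either. Compound 4 is therefore estimated at 22 ug/mL, within a range of 11 ug/mL to 45 ug/mL. The expected step is a 1.1-fold lower number from compound 2 to compound 4 (0.02 log units; within the scatter).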

Compound 4, concentration for half-maximal effect: 39.3 ug/mL
Compound 4: middle estimate off by 1.8-fold (0.25 log units), on the low side, and the stated range covers the measured number.
By their numbers in this assay, from the lowest: compounds 1, 3, 2 and 4 (each within the scatter of the next, the first and the last beyond it).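

Going by these compounds alone, exchanging methoxy for hydroxy on the aromatic ring, a change that none of the earlier steps touched, gives a 1.7-fold higher number from compound 2 to compound 4 (0.23 log units; within the scatter) in this assay. Within the data shown here, the 3-hydroxyphenyl group is also the only aryl group here to separate from others beyond the scatter, with a 2.5-fold higher number from compound 3 to compound 4 (0.39 log units; beyond the scatter) and a 2.6-fold higher number from compound 1 to compound 4 (0.41 log units; beyond the scatter), although compound 2 remains within the scatter of compound 4. Nothing available accounts for these steps.

The compounds shown leave open how an amine or a longer alkoxy chain in place of this hydroxy would read in this assay. They also leave open whether replacing methoxy with hydroxy in the 2,4-dimethoxyphenyl group of compound 3 would give a similar step.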